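Replacing cyano with 2-cyanoethenyl in compound 2

This account rests on a few compounds, and the source may have more. Where it says the series, first, only, none or still open, it means among the compounds named here.

compound 1 `Cc1cc(C#N)cc(C)c1Oc1cc(Nc2ccc(C#N)cc2)c(N)cc1CNCCCO`: 15100 nM
compound 2 `COCc1cc(N)c(Nc2ccc(C#N)cc2)cc1Oc1c(C)cc(C#N)cc1C`: 146000 nM

In an ADME assay on MT2 cells (Homo sapiens) for cytotoxicity (a higher number here means that more compound is tolerated, a lower number that less compound is tolerated), compound 2 holds the higher of the two numbers, at 146000 nM. Compound 3 `COCc1cc(N)c(Nc2ccc(C#N)cc2)cc1Oc1c(C)cc(/C=C/C#N)cc1C` differs from it in one group: 2-cyanoethenyl in place of cyano on an aromatic carbon. The 2-cyanoethenyl takes the place of cyano on an aromatic carbon, para to a large group. Going by the values given here, the only measured step, a 9.7-fold higher number from compound 1 to compound 2 (0.99 log units; beyond the scatter), lies elsewhere, on a saturated chain carbon bound to an aromatic carbon. It gives no direction for this change, only a size for one change in the series. With compound 2 at 146000 nM as the higher end of the data, a lower number of similar or smaller size is expected. The expected change is a 2.9-fold lower number from compound 2 to compound 3 (0.47 log units; beyond the scatter). For compound 3 an estimated 50000 nM is expected, within 12000 nM to 170000 nM.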

Compound 3, half-maximal cytotoxic concentration: 50300 nM
Beside the measured number, compound 3's estimate is 1.0-fold (0.00 log units) below it, within the range that was stated.
By their numbers in this assay, from the lowest: compound 1; then compound 3; then compound 2.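

In this assay, the position on an aromatic carbon, meta to two methyl groups, now has a measured step of its own: a 2.9-fold lower number from compound 2 to compound 3 (0.46 log units; beyond the scatter), with 2-cyanoethenyl in place of cyano. The earlier step, a 9.7-fold higher number from compound 1 to compound 2 (0.99 log units; beyond the scatter), lay on a saturated chain carbon bound to an aromatic carbon, whereas this one shows that the larger group at the new position goes with less compound tolerated, although the donor and acceptor counts of the two groups are the same. Nothing on hand bears on why the number falls with this change.

From the compounds shown here alone, whether a saturated 2-cyanoethyl chain, an amine or a carboxylic acid at this position would give a step in the same direction remains open. Also open, going by these compounds, is whether 2-cyanoethenyl gives a step of similar size when (3-hydroxypropyl)amino replaces methoxy on the chain carbon.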